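A few compounds are considered here, and "the series" means these few. Any claim that something is new, unique, unknown or untested is made for them only; others in the source may bear on it.

Measured compounds:
Compound 1, `CS(=O)(=O)CCCOc1ccc2c(c1)OC(COc1ccc(CCC(=O)O)c(F)c1)CC2`, in a functional assay on HEK293 cells for agonist activity at Free fatty acid receptor 1 (Homo sapiens), read by fluorescence and calcium flux, with a stated time of 10 min (on this read-out higher numbers stand for larger maximal responses and lower numbers for smaller maximal responses), gives 38%.
Compound 2, `CC#C[C@@H](CC(=O)O)c1ccc(OC[C@H]2COc3ccc(C)cc3O2)cc1`, in this assay gives 78%.

Of the two numbers recorded, compound 2 stands highest; the nearest is compound 1, whose value lies well below it, a gap beyond the usual scatter. Going by the values given here, no pair of measured compounds differs in a single place, so no measured step is available to guide the next change, and the two values simply show what they show.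

Compound 3, `CC#C[C@@H](CC(=O)O)c1ccc(OC[C@H]2COc3ccc(C(=O)N(C)C)cc3O2)cc1`, has not yet been measured in this assay. It differs from compound 2 in one place: dimethylcarbamoyl in place of methyl on an aromatic carbon. Among the compounds with values here, no measured step involves this kind of change, so what follows rests only on the value of compound 2 and the fact that the rest of the structure is kept.

For compound 3 the step of a number 6 percentage points lower from compound 2 to compound 3 (within the scatter) is expected to stay within the usual scatter, with no clear direction. Compound 3 is therefore estimated to give 72% in this assay, with a range from 50% to 95%.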

Compound 3, largest response reached (Emax), in percent of the reference or control that the assay uses: 32%
Compound 3: middle estimate off by 40 percentage points, on the high side; measured number outside the range, below it.
By their numbers in this assay, from the lowest: compounds 3 and 1 (each within the scatter of the next); then compound 2.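

Going by these compounds alone, replacing methyl with dimethylcarbamoyl on this aromatic carbon, meta to a fused ring and para to a fused ring, gives a number 46 percentage points lower from compound 2 to compound 3 (beyond the scatter) in this assay, and this is the first single-place step. The position is therefore not a neutral one for the largest response reached: keeping the rest of the structure of compound 2 does not by itself preserve the response once dimethylcarbamoyl enters here. No supporting measurement bears on why the response falls with this change.

A single step cannot show which part of dimethylcarbamoyl goes with the lower response, and a primary carboxamide, an acetyl or a monomethyl carboxamide at the same carbon would help separate the carbonyl from the two methyl groups on nitrogen. Going by these compounds, it also remains open whether small groups such as ethyl, methoxy or chloro hold the response near that of compound 2, and whether the same change would give a step of similar size on a different core.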